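Series notes: from compound 2 to compound 4

The source may report more compounds than this note shows. Statements on the series, on what has been measured and on what is new or still open speak of the compounds shown alone.

Compound 1 `CNC(=O)[C@@H](CO)NCc1ccc(OCc2ccc(Cl)cc2)cc1` gives 216 mg/kg
Compound 2 `CNC(=O)[C@@H](CO)NCc1ccc(OCc2cccc(C)c2)cc1` gives 41.3 mg/kg
Compound 3 `CNC(=O)[C@@H](CO)NCc1ccc(OCc2cccc(C(F)(F)F)c2)cc1` gives 19.5 mg/kg
Compound 4 `CNC(=O)[C@@H](CO)NCc1ccc(OCc2ccccc2F)cc1` has not yet been measured

Compound 2 at 41.3 mg/kg stands second highest of the three numbers in a functional assay on the whole organism with Mus musculus as the target (a higher number here means that more compound is needed for the effect, a lower number that less compound is needed), so far. Compound 4 carries 2-fluorophenyl in place of 3-methylphenyl on a saturated chain carbon bound to an oxygen on an aromatic ring. The step of a 5.2-fold lower number from compound 1 to compound 2 (0.72 log units; beyond the scatter) is an exchange at the same place, and the step of a 2.1-fold lower number from compound 2 to compound 3 (0.33 log units; beyond the scatter) is a smaller change on the same group. Neither involves 2-fluorophenyl, so they set no direction, and no step beyond the scatter is expected in this assay although a modest one remains possible. An estimated 1.2-fold lower number from compound 2 to compound 4 (0.07 log units; within the scatter) is what this means. Compound 4 is estimated at 35 mg/kg with 12 mg/kg to 100 mg/kg as the expected range.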

Compound 4, dose for half-maximal effect: 12.4 mg/kg
The estimate for compound 4 lay 2.8-fold (0.45 log units) above the measured number; the range from low to high includes it.
By their numbers in this assay, from the lowest: compounds 4 and 3 (each within the scatter of the next); then compound 2; then compound 1.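

In this assay, the group on a saturated chain carbon bound to an oxygen on an aromatic ring still moves the dose when 2-fluorophenyl enters: a 3.3-fold lower number from compound 2 to compound 4 (0.52 log units; beyond the scatter), and a 17-fold lower number from compound 1 to compound 4 (1.24 log units; beyond the scatter). The earlier compounds shown here showed low numbers only with methyl or trifluoromethyl on the ring, whereas a single fluorine now also gives a low number, with compound 4 and compound 3 within the scatter of each other.

On these data alone, whether unsubstituted phenyl, 2-chlorophenyl or pyridyl would match 2-fluorophenyl remains open. No measurement shown explains these steps.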